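Swapping a chloro for a methoxy on the chalcone ring

This account rests on a few compounds, and the source may have more. Where it says the series, first, only, none or still open, it means among the compounds named here.

Three related compounds have been tested in a functional assay on the whole organism (Abdomen, strain Swiss) with Mus musculus as the target, with a stated time of 30 min; on this read-out lower numbers stand for an effect already at smaller amounts and higher numbers for an effect only at larger amounts of compound. Compound 1 `Cc1ccc(/C=C/C(=O)c2ccc(NC(=O)Nc3ccc(Cl)cc3)cc2)cc1` gives 39.7 umol/kg. Compound 2 `O=C(Nc1ccc(Cl)cc1)Nc1ccc(C(=O)/C=C/c2ccccc2)cc1` gives 7.25 umol/kg. Compound 3 `O=C(Nc1ccc(Cl)cc1)Nc1ccc(C(=O)/C=C/c2ccc(Cl)cc2)cc1` gives 45.4 umol/kg. Of the three numbers, compound 3 has the highest, but the step of a 1.1-fold higher number from compound 1 to compound 3 (0.06 log units; within the scatter) lies within the scatter, so these two cannot be told apart; only compound 2 stands clearly apart, with a 6.3-fold higher number from compound 2 to compound 3 (0.80 log units; beyond the scatter), and likewise a 5.5-fold lower number from compound 1 to compound 2 (0.74 log units; beyond the scatter).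

Compound 4 `COc1ccc(/C=C/C(=O)c2ccc(NC(=O)Nc3ccc(Cl)cc3)cc2)cc1` differs from compound 3 in one place: methoxy in place of chloro on an aromatic carbon. Among the compounds with values here, no measured step here involves a methoxy, so the expectation must rest on the steps that touch the same position. Putting chloro in place of hydrogen, or methyl in place of hydrogen, raised the number clearly, while exchanging methyl and chloro changed nothing beyond the scatter. A methoxy is another group at this position, and on that basis a number close to compound 3 seems most likely, with the risk spread toward both sides. The step that this estimate implies, a 1.3-fold lower number from compound 3 to compound 4 (0.11 log units; within the scatter), is expected to be small. Compound 4 is therefore estimated to give about 35 umol/kg, within a range from 12 umol/kg to 100 umol/kg.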

Compound 4, dose for 50% inhibition: 31.1 umol/kg
Compound 4: the middle estimate sits 1.1-fold (0.05 log units) above what was measured, and the stated range covers the measured number.
By their numbers in this assay, from the lowest: compound 2; then compounds 4, 1 and 3 (each within the scatter of the next).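

Compound 4 puts a third kind of group at this position, one that brings an oxygen and a hydrogen-bond acceptor where chloro has neither, yet in this assay both a 1.5-fold lower number from compound 3 to compound 4 (0.16 log units; within the scatter) and a 1.3-fold lower number from compound 1 to compound 4 (0.11 log units; within the scatter) stay within the scatter, so methoxy, chloro and methyl cannot be told apart here. Only hydrogen stands apart: a 4.3-fold higher number from compound 2 to compound 4 (0.63 log units; beyond the scatter) is beyond the scatter, so methoxy now joins methyl and chloro in giving a clearly higher number than hydrogen, and none of the four compounds goes against this. Until now that contrast rested on two groups with no oxygen, whereas here it holds for a group joined to the ring through an oxygen, and among these compounds the number tracks whether hydrogen has been replaced rather than which of the three groups replaced it.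

Nothing in the data shown explains why hydrogen differs from the other three groups. As far as these compounds go, whether fluoro, an amine, a carboxylic acid or a longer chain such as butoxy at this same position would also give a number like those of compound 1, compound 3 and compound 4 remains open.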